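The source may hold more compounds than are shown below. What is called first, only, known or untested is meant among the compounds shown, and "the series" means these compounds.

Series notes. Compound 2 `CC(C)Cc1ccc(C(C)c2nnc3n2N=C(c2ccc(OC(F)(F)F)cc2)CS3)cc1` carries the lowest number of the three measured compounds in a functional assay on MCF7 cells (Homo sapiens) for inhibition, read by sulforhodamine B assay, with a stated time of 72 h (on this read-out higher numbers stand for weaker inhibition and lower numbers for stronger inhibition), giving 1100 nM. Compound 1 `COc1ccc2cc(C(C)c3nnc4n3N=C(c3ccc(C(F)(F)F)cc3)CS4)ccc2c1` in this assay gives 6900 nM, and compound 3 `COc1ccc2cc(C(C)c3nnc4n3N=C(c3ccc(Br)cc3)CS4)ccc2c1` gives 11500 nM; both gaps from compound 2 lie beyond the scatter, so compound 2 is the strongest inhibitor measured so far. Compound 4 `CC(C)Cc1ccc(C(C)c2nnc3n2N=C(c2ccc([N+](=O)[O-])cc2)CS3)cc1` is not yet measured. Its change from compound 2: nitro in place of trifluoromethoxy on an aromatic carbon. Among the compounds with values here, the only measured single-point step, a 1.7-fold higher number from compound 1 to compound 3 (0.22 log units; within the scatter), likewise exchanges one group for another on an aromatic carbon of the six-membered aromatic ring of carbon only, and it stays within the scatter; it is the nearest precedent, though it sits on a different core from the one compound 2 and compound 4 share. On that precedent, a swap of the group at this place is expected to move this assay little, with no firm direction, and a slight rise in the number is allowed for. Compound 4 is therefore expected at 1800 nM, with a range of 600 nM to 5500 nM. This amounts to an expected step of a 1.6-fold higher number from compound 2 to compound 4 (0.21 log units; within the scatter).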

Compound 4, half-maximal inhibitory concentration: "not active" (no number reported)
The entry for compound 4 holds no number; there is nothing to compare the estimate with.
By their numbers in this assay, from the lowest: compound 2; then compounds 1 and 3 (each within the scatter of the next).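

Within the data shown here, compound 4 is recorded as "not active" in this assay without a number, so no step from compound 2 can be read. The compounds shown leave open how far nitro and trifluoromethoxy differ at this place on the shared core. Nothing shown explains this result.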